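Pyrrolidine amide in place of aminopyridine amide

This account rests on a few compounds, and the source may have more. Where it says the series, first, only, none or still open, it means among the compounds named here.

Compound 1 `O=C(c1ccc(Cl)nc1)N1CCC(NS(=O)(=O)c2cc(S(=O)(=O)c3ccccc3)ccc2C(F)(F)F)CC1` gives 25000 nM in a physicochemical assay for solubility; a higher number here means a more soluble compound, a lower number a less soluble compound. Compound 2 `CN(C)c1ccc(C(=O)N2CCC(NS(=O)(=O)c3cc(S(=O)(=O)c4ccccc4)ccc3C(F)(F)F)CC2)cn1` gives 12500 nM and so stands lowest of the two numbers, though the step of a 2.0-fold lower number from compound 1 to compound 2 (0.30 log units; within the scatter) lies within the scatter. Compound 3 `O=C([C@H]1CCNC1)N1CCC(NS(=O)(=O)c2cc(S(=O)(=O)c3ccccc3)ccc2C(F)(F)F)CC1` carries the change (pyrrolidin-3-yl in place of 6-(dimethylamino)pyridin-3-yl on a carbonyl carbon). Going by the values given here, the only measured step, a 2.0-fold lower number from compound 1 to compound 2 (0.30 log units; within the scatter), concerns a substituent swap on the aromatic ring and does not bear on exchange of the whole ring; no measured step covers this change. A rise is nonetheless expected, a 4.8-fold higher number from compound 2 to compound 3 (0.68 log units; beyond the scatter). For compound 3 the estimate is 60000 nM, range 15000 nM to 250000 nM.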

Compound 3, solubility: 25000 nM
Compound 3: middle estimate off by 2.4-fold (0.38 log units), on the high side; low and high end bracket the measured number.
By their numbers in this assay, from the lowest: compounds 2, 1 and 3 (each within the scatter of the next).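

At the carbonyl carbon, the whole aromatic ring can be exchanged, not just a substituent on it: in this assay, pyrrolidin-3-yl in place of 6-(dimethylamino)pyridin-3-yl gives a 2.0-fold higher number from compound 2 to compound 3 (0.30 log units; within the scatter) and, in place of 6-chloropyridin-3-yl, no change at the digits printed from compound 1 to compound 3 (within the scatter). Aromatic and non-aromatic rings at this position are therefore not separated by this read-out. Nothing available accounts for this outcome.

Whether a piperidin-4-yl ring, an open-chain amine or a carboxylic acid at the same carbon would stay within the scatter of these compounds remains open. As far as these compounds go, the opposite configuration of the pyrrolidin-3-yl stereocentre also remains open.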